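A Branched Alkyne Substituent on the Shared Core

A few compounds are considered here, and "the series" means these few. Any claim that something is new, unique, unknown or untested is made for them only; others in the source may bear on it.

Compound 1 `O=c1[nH]c(=O)n(CCC(CO)CO)cc1-c1cccs1` carries a thiophen-2-yl group on the shared core, and in a functional assay on HeLa cells (Homo sapiens) for antiproliferative activity, read by MTT assay, with a stated time of 72 h (a higher number here means a weaker inhibitor, a lower number a stronger inhibitor), compound 1 gives 7800 nM. Compound 2 `CCCCCC#Cc1cn(CCC(CO)CO)c(=O)[nH]c1=O` carries a hept-1-yn-1-yl group in its place, and in this assay compound 2 gives 76300 nM; the step of a 9.8-fold higher number from compound 1 to compound 2 (0.99 log units; beyond the scatter). Compound 3 `CCCCCCCCC#Cc1cn(CCC(CO)CO)c(=O)[nH]c1=O` extends the chain on that alkyne, and in this assay compound 3 gives 58900 nM, so that the step of a 1.3-fold lower number from compound 2 to compound 3 (0.11 log units; within the scatter). Compound 3 thus stands second highest of the three numbers, close to compound 2 and far from compound 1. Compound 4 `CC(C)(C)C#Cc1cn(CCC(CO)CO)c(=O)[nH]c1=O` differs from compound 3 by tert-butyl in place of octyl on a triple-bonded carbon. For the measured compounds named here, the one measured step that bears on a change in the chain attached to the triple-bonded carbon is a 1.3-fold lower number from compound 2 to compound 3 (0.11 log units; within the scatter), and it was small. Going by the values given here, no measured step shows a branched group at this position, so the direction of any effect is unknown. The step of a 1.0-fold higher number from compound 3 to compound 4 (0.01 log units; within the scatter) is therefore expected to be small. Compound 4 is estimated at 60000 nM in this assay, with a range from 20000 nM to 180000 nM.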

Compound 4, half-maximal inhibitory concentration: > 100000 nM
Compound 4 ended at the assay's limit; the forecaster's own chance of this, stated with the estimate: 10%; middle value at least 1.6-fold (0.22 log units) away from the limit.
By their numbers in this assay, from the lowest: compound 1; then compounds 3 and 2 (each within the scatter of the next). At a limit, above all of these: compound 4.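

In this assay compound 4 reaches a limit and gives no number: the limit of > 100000 nM in this assay, at which 1 of the 4 values shown sits. Putting tert-butyl on the triple-bonded carbon in place of a straight chain therefore gives only floors, an at least 1.6-fold higher number from compound 3 to compound 4 (0.22 log units; that floor lies within the scatter) and an at least 1.3-fold higher number from compound 2 to compound 4 (0.11 log units; that floor lies within the scatter), and since both floors lie within the scatter, the true size of these steps cannot be read. The change from thiophen-2-yl to 3,3-dimethylbut-1-yn-1-yl gives an at least 12-fold higher number from compound 1 to compound 4 (1.10 log units; beyond the scatter), so this first branched group at the position, like the straight chains, falls well short of thiophen-2-yl.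

As far as these compounds go, whether a phenyl ring on the triple-bonded carbon would bring the number back towards that of thiophen-2-yl stays open. The compounds shown also leave open what a hydroxyl group or an amine at the end of the chain would do.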